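The source may hold more compounds than are shown below. What is called first, only, known or untested is meant among the compounds shown, and "the series" means these compounds.

Measured compounds in an assay on isolated protein for inhibition of receptor-type tyrosine-protein phosphatase C (Homo sapiens), read by spectrophotometry; on this read-out higher numbers stand for weaker inhibition and lower numbers for stronger inhibition:
- compound 1 `O=C(COc1ccc2cc(C(O)(C(F)(F)F)C(F)(F)F)c(O)cc2c1)Nc1nc2ccccc2s1`: 10900 nM
- compound 2 `COc1ccc(CNC(=O)COc2ccc3cc(C(O)(C(F)(F)F)C(F)(F)F)c(O)cc3c2)cc1OC`: > 20000 nM

For compound 2 this assay gives only a limit, (the limit of > 20000 nM in this assay, at which 1 of the 2 values shown sits). Going by the values given here, the one measured step, an at least 1.8-fold higher number from compound 1 to compound 2 (0.26 log units; that floor lies within the scatter), runs from a measured value to that limit, so compound 2 stands no better than compound 1 and possibly well weaker. Compound 3 `Cc1ccc(S(=O)(=O)NNC(=O)COc2ccc3cc(C(O)(C(F)(F)F)C(F)(F)F)c(O)cc3c2)cc1` changes compound 2 by ((4-methylphenyl)sulfonyl)amino in place of 3,4-dimethoxybenzyl on an amide-type nitrogen. Among the compounds with values here, no measured step bears on this exchange; the only neighbour is itself a limit, so a number near or past that limit is expected, a number no higher from compound 2 to compound 3 (the limit leaves the size open). Compound 3 is estimated at 20000 nM, range 7000 nM to 60000 nM.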

Compound 3, half-maximal inhibitory concentration: 16100 nM
Compound 3: middle estimate off by 1.2-fold (0.09 log units), on the high side, within the range that was stated.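

In this assay, the ((4-methylphenyl)sulfonyl)amino group gives this place on the amide-type nitrogen a second measured value, with a sulfonyl-linked group now alongside 1,3-benzothiazol-2-yl. The step of a 1.5-fold higher number from compound 1 to compound 3 (0.17 log units; within the scatter) does not separate these two groups. The step of an at least 1.2-fold lower number from compound 2 to compound 3 (0.09 log units; that floor lies within the scatter) has no fixed size and rests on a limit for compound 2: the limit of > 20000 nM in this assay, at which 1 of the 3 values shown sits.

From the compounds shown here alone, whether any group here can move the number beyond the scatter stays open. A carboxylic acid or a longer chain in this place on the amide-type nitrogen would test that.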